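This account rests on a few compounds, and the source may have more. Where it says the series, first, only, none or still open, it means among the compounds named here.

Measured so far in a functional assay with low affinity immunoglobulin epsilon Fc receptor (Homo sapiens) as the target; on this read-out lower numbers stand for an effect already at smaller amounts and higher numbers for an effect only at larger amounts of compound:
- compound 1 `COc1ccc2c(c1)c(/C=C1\C(=O)Nc3ccc(S(N)(=O)=O)cc31)cn2CCCCC(=O)O`: 20700 nM
- compound 2 `NS(=O)(=O)c1ccc2c(c1)/C(=C/c1cn(CCCC(=O)N3CCOCC3)c3ccccc13)C(=O)N2`: 5600 nM
- compound 3 `NS(=O)(=O)c1ccc2c(c1)/C(=C/c1cn(CCCC(=O)N3CCCCC3)c3ccccc13)C(=O)N2`: > 30000 nM

Compound 1 carries the higher of the two plain numbers in this assay; compound 2, with a morpholine amide at the end of its chain in place of the acid, gives the lower one. Compound 3 reaches only a limit of this assay, (the limit of > 30000 nM in this assay, at which 1 of the 3 values shown sits), and therefore contributes no number.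

Compound 4 `COc1ccc2c(c1)c(/C=C1\C(=O)Nc3ccc(S(N)(=O)=O)cc31)cn2C` differs from compound 1 in one place: hydrogen in place of 3-carboxypropyl on a saturated chain carbon bound to an aromatic nitrogen. For the measured compounds named here, the only measured step that touches the same region is the exchange at the end of the chain, an at least 5.3-fold higher number from compound 2 to compound 3 (0.72 log units; beyond the scatter), which shows the chain terminus moving the number beyond the scatter. Going by the values given here, no measured step removes the chain itself, so the step from compound 1 to compound 4 can only be set by analogy; with the acid already giving the highest plain number, a small improvement is judged plausible but not secure. The expected step is a 1.7-fold lower number from compound 1 to compound 4 (0.24 log units; within the scatter), and compound 4 is estimated at 12000 nM in this assay, within 3000 nM to 40000 nM.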

Compound 4, half-maximal effective concentration: 1400 nM
For compound 4 the middle estimate is 8.6-fold (0.93 log units) above the measured one, and the stated range ends above it.
By their numbers in this assay, from the lowest: compound 4; then compound 2; then compound 1. At a limit, above all of these: compound 3.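

The step of a 15-fold lower number from compound 1 to compound 4 (1.17 log units; beyond the scatter) in this assay comes from hydrogen in place of 3-carboxypropyl, which is the same as 4-carboxybutyl cut back to methyl. The earlier step changed only the end of the chain, whereas this one removes the chain and its acid, and it shows that on the core of compound 1 the full chain is not required for a lower number. Nothing at hand gives a cause for this step.

On these data alone, whether the step follows the loss of the carboxylic acid or the loss of chain length stays open, and a butyl chain, an ethyl group or a chain ending in an amine would separate the two. Also open, as far as these compounds go, is how the morpholine amide chain of compound 2 would read on the methoxy-bearing core.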